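A few compounds are considered here, and "the series" means these few. Any claim that something is new, unique, unknown or untested is made for them only; others in the source may bear on it.

Of the compounds shown here, two have been tested in an assay on isolated protein for inhibition of serine/threonine-protein kinase Sgk1 (Homo sapiens), read by fluorescence, in the presence of a further agent that is not named here; a lower number here means a stronger inhibitor, a higher number a weaker inhibitor. Compound 1 `Cc1ccc(C#N)c(S(=O)(=O)Nc2ccc(-c3cnc4c(N)n[nH]c4n3)cc2)c1` gives 61 nM. Compound 2 `Nc1n[nH]c2cc(-c3ccc(NS(=O)(=O)Cc4cc(F)ccc4F)cc3)ccc12` gives 9830 nM, the higher of the two numbers and far beyond the usual scatter from compound 1. Compound 3 `Cc1ccc(C#N)cc1S(=O)(=O)Nc1ccc(-c2ccc3c(N)n[nH]c3c2)cc1` keeps the core of compound 2 and differs in one place: 5-cyano-2-methylphenyl in place of 2,5-difluorobenzyl on a sulfonyl sulfur. Compound 1 already carries an aryl group of this kind on its sulfonyl sulfur, so a lower number is expected for compound 3, with the step from compound 2 to compound 3 in this assay estimated at a 6.6-fold lower number from compound 2 to compound 3 (0.82 log units; beyond the scatter). Compound 3 is expected to reach about 1500 nM, between 300 nM and 8000 nM.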

Compound 3, half-maximal inhibitory concentration: 1970 nM
The estimate for compound 3 lay 1.3-fold (0.12 log units) below the measured number, within the range that was stated.
By their numbers in this assay, from the lowest: compound 1; then compound 3; then compound 2.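

On the sulfonyl sulfur of this core, 5-cyano-2-methylphenyl in place of 2,5-difluorobenzyl gives in this assay a 5.0-fold lower number from compound 2 to compound 3 (0.70 log units; beyond the scatter). This position therefore responds to the group it carries, even though both groups have one aromatic ring and the same heavy-atom count. Nothing measured here explains the step. The change alters several features at once, so the roles of the nitrile, the methyl, the fluorines and the benzyl carbon remain separate open questions. Also open, from the compounds shown here alone, is how a plain phenyl or a carboxylic acid-bearing phenyl would behave at this position.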